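This account rests on a few compounds, and the source may have more. Where it says the series, first, only, none or still open, it means among the compounds named here.

Among the compounds with values here, in a physicochemical assay for permeability, using PAMPA, with a stated time of 4 h, at pH 6.2, tested at 50 uM (on this read-out higher numbers stand for higher permeability and lower numbers for lower permeability), compound 1 `Cc1c(CCCC(=O)O)c2cccc(/C=C/c3ccc(OCCCCc4c(F)c(F)cc(F)c4F)cc3)c2n1CC(=O)O` gives 9.4 10^-6 cm/s, the highest of the two numbers measured so far; compound 2 `Cc1c(F)cccc1CCCCOc1ccc(/C=C/c2cccc3c(CCCC(=O)O)cn(CC(=O)O)c23)cc1` gives 3.5 10^-6 cm/s, a step beyond the scatter below compound 1. Within the data shown here, no two measured compounds differ in a single place, so no step can be read from them. Compound 3 `Cc1c(CCCC(=O)O)c2cccc(/C=C/c3ccc(OCCCCc4cc(F)c(F)c(F)c4F)cc3)c2n1CC(=O)O` has not yet been measured; it differs from compound 1 as follows: 2,3,4,5-tetrafluorophenyl in place of 2,3,5,6-tetrafluorophenyl on a saturated chain carbon, four bonds along the chain from an oxygen on an aromatic ring. With the same atoms joined differently and nothing counted as gained or lost, no step beyond the scatter is expected from compound 1 to compound 3 in this assay. Compound 3 is expected to give 9 10^-6 cm/s, with a range from 5 10^-6 cm/s to 16 10^-6 cm/s, which means an expected 1.0-fold lower number from compound 1 to compound 3 (0.02 log units; within the scatter).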

Compound 3, apparent permeability: 1.8 10^-6 cm/s
For compound 3 the middle estimate is 5.0-fold (0.70 log units) above the measured one; measured number below the stated range.
By their numbers in this assay, from the lowest: compounds 3 and 2 (each within the scatter of the next); then compound 1.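

In this assay the placing of the fluorines on this ring matters: 2,3,4,5-tetrafluorophenyl in place of 2,3,5,6-tetrafluorophenyl gives a 5.2-fold lower number from compound 1 to compound 3 (0.72 log units; beyond the scatter), although the atoms and the counted features stay the same. At this position on the saturated chain, the read-out therefore follows the fluorine pattern, not just the group's composition. Nothing at hand bears on the cause of this step. From the compounds shown here alone, it remains open whether a pentafluorophenyl group would read nearer compound 1 or compound 3. Also open, going by these compounds, is whether the same change would give a similar step on a shorter chain.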